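The source may hold more compounds than are shown below. What is called first, only, known or untested is meant among the compounds shown, and "the series" means these compounds.

Measured compounds:
- Compound 1, `COc1ccc(/C=C/c2cc(OC)cc(OC)c2/C=C/C(=O)c2ccc(Cl)c(Cl)c2)cc1`: 10.8 ug/mL
- Compound 2, `CCCCOc1ccc(C(=O)/C=C/c2c(/C=C/c3ccc(OC)cc3)cc(OC)cc2OC)cc1`: 12.9 ug/mL
- Compound 3, `COc1ccc(/C=C/c2cc(OC)cc(OC)c2/C=C/C(=O)c2ccc(Br)cc2)cc1`: 12.9 ug/mL

These three compounds were tested in a functional assay on HepG2 cells (Homo sapiens) for antiproliferative activity, read by MTT assay, with a stated time of 48 h; on this read-out higher numbers stand for weaker inhibition and lower numbers for stronger inhibition. All three share one core and differ only in the aryl group attached to the carbonyl carbon. The three numbers lie so close together that none of the compounds can be set apart: the step of a 1.2-fold higher number from compound 1 to compound 2 (0.08 log units; within the scatter) and the step of a 1.2-fold higher number from compound 1 to compound 3 (0.08 log units; within the scatter) are both within the scatter of repeated measurements, and the step of no change at the digits printed from compound 2 to compound 3 (within the scatter) is likewise within it. Compound 1 therefore stands among its neighbours rather than apart from them.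

Compound 4, `COc1ccc(/C=C/c2cc(OC)cc(OC)c2/C=C/C(=O)c2ccc(OC)cc2)cc1`, has not yet been measured in this assay. It differs from compound 1 in one place: 4-methoxyphenyl in place of 3,4-dichlorophenyl on a carbonyl carbon.

The two measured steps that bear on this change, those from compound 1 to compound 2 and from compound 1 to compound 3, each swapped the same 3,4-dichlorophenyl for another aryl group on the carbonyl carbon, and each moved the number by an amount within the scatter. The expectation for compound 4 is therefore a step of no meaningful size, a 1.1-fold higher number from compound 1 to compound 4 (0.05 log units; within the scatter). Compound 4 is estimated to give 12 ug/mL in this assay, with a range from 6 ug/mL to 25 ug/mL.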

Compound 4, half-maximal inhibitory concentration: 4.9 ug/mL
Compound 4: the middle estimate sits 2.4-fold (0.39 log units) above what was measured, outside the stated range (below it).
By their numbers in this assay, from the lowest: compound 4; then compounds 1, 2 and 3 (each within the scatter of the next).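

In this assay the aryl group on the carbonyl carbon proves able to shift the number: placing 4-methoxyphenyl in the position of 3,4-dichlorophenyl gives a 2.2-fold lower number from compound 1 to compound 4 (0.34 log units; beyond the scatter), a modest step, while the earlier swaps among 3,4-dichlorophenyl, 4-bromophenyl and 4-butoxyphenyl all stayed within the scatter. Methoxy in place of bromo on the aromatic carbon gives a step of similar reading, a 2.6-fold lower number from compound 3 to compound 4 (0.42 log units; beyond the scatter), so the result does not rest on the comparison with 3,4-dichlorophenyl alone. An oxygen on the aryl ring is not enough by itself, as 4-butoxyphenyl cannot be told apart from the two halogen-bearing groups, and cutting butoxy down to methoxy gives a 2.6-fold lower number from compound 2 to compound 4 (0.42 log units; beyond the scatter), which ties the gain among these compounds to methoxy rather than to every oxygen-linked chain.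

Nothing available here accounts for why methoxy behaves differently from the other groups. Whether an ethoxy chain, a hydroxy group or an amine on this aryl ring would match methoxy stays open, so the compounds shown cannot say how narrow this modest effect is.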